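A few compounds are considered here, and "the series" means these few. Any claim that something is new, unique, unknown or untested is made for them only; others in the source may bear on it.

In a functional assay on SGC-7901 cells (Homo sapiens) for antiproliferative activity, read by MTT assay, with a stated time of 24 h (on this read-out higher numbers stand for weaker inhibition and lower numbers for stronger inhibition), the measured compounds are:
compound 1 `O=C(NNc1ccccc1F)c1ccc(NS(=O)(=O)c2cnc(O)nc2O)cc1` with 16000 nM
compound 2 `O=C(NNC(=O)c1ccccc1Cl)c1ccc(NS(=O)(=O)c2cnc(O)nc2O)cc1` with 3240 nM

Compound 2 holds the lower of these two numbers. Compound 3 `O=C(NNC(=O)c1cccc(Cl)c1)c1ccc(NS(=O)(=O)c2cnc(O)nc2O)cc1` has the same atoms joined differently, with 3-chlorophenyl in place of 2-chlorophenyl on a carbonyl carbon. Among the compounds with values here, the one measured step is a 4.9-fold lower number from compound 1 to compound 2 (0.69 log units; beyond the scatter) and it exchanged different groups, so it bears only loosely here. Within the data shown here, no measured pair moves a chlorine, so the direction is open. In this assay the expected change is small, with the estimate being a 1.2-fold higher number from compound 2 to compound 3 (0.09 log units; within the scatter) as a best guess. Compound 3 is expected at 4000 nM with an estimated range from 1300 nM to 11000 nM as its limits of expectation.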

Compound 3, half-maximal inhibitory concentration: 8610 nM
Beside the measured number, compound 3's estimate is 2.2-fold (0.33 log units) below it, and the stated range covers the measured number.
By their numbers in this assay, from the lowest: compound 2; then compounds 3 and 1 (each within the scatter of the next).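

In this assay, moving the chlorine from 2-chlorophenyl to 3-chlorophenyl on a carbonyl carbon, with no atom added or lost, gives a 2.7-fold higher number from compound 2 to compound 3 (0.42 log units; beyond the scatter), so the place of the chlorine counts here. The 3-chlorophenyl group also loses the clear separation from the first compound: the change is a 1.9-fold lower number from compound 1 to compound 3 (0.27 log units; within the scatter). Nothing measured here explains the effect of moving the chlorine.

Still open, as far as these compounds go, is whether this sensitivity is specific to chlorine. A 3-methoxyphenyl or 3-aminophenyl group on the same carbonyl carbon would test that.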